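Swapping 4-methoxyphenyl for thiophen-3-yl on a shared core

The source may report more compounds than this note shows. Statements on the series, on what has been measured and on what is new or still open speak of the compounds shown alone.

Measured in a functional assay on CAPAN-1 cells (Homo sapiens) for antiproliferative activity, with a stated time of 72 h; a higher number here means a weaker inhibitor, a lower number a stronger inhibitor:
- Compound 1 `Nc1ncnn2c([C@@H]3O[C@H](CO)[C@@H](O)[C@H]3O)cc(C#Cc3ccc(F)cc3)c12`: 55400 nM
- Compound 2 `Nc1ncnn2c([C@@H]3O[C@H](CO)[C@@H](O)[C@H]3O)cc(C#Cc3ccccc3)c12`: 37700 nM
- Compound 3 `COc1ccc(-c2cc([C@@H]3O[C@H](CO)[C@@H](O)[C@H]3O)n3ncnc(N)c23)cc1`: 43900 nM

The value of compound 3 lies within the scatter of both other values, so the three cannot be put in any order. Compound 4 `Nc1ncnn2c([C@@H]3O[C@H](CO)[C@@H](O)[C@H]3O)cc(-c3ccsc3)c12` keeps the shared core and has thiophen-3-yl in place of 4-methoxyphenyl on an aromatic carbon. This carbon sits two ring bonds from the ring atom that bears a 3,4-dihydroxy-5-(hydroxymethyl)oxolan-2-yl group.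

Two measured steps exchange the group at this same place: a 1.3-fold lower number from compound 1 to compound 3 (0.10 log units; within the scatter) and a 1.2-fold higher number from compound 2 to compound 3 (0.07 log units; within the scatter). A third, a 1.5-fold lower number from compound 1 to compound 2 (0.17 log units; within the scatter), only swaps fluoro for hydrogen further out on the group. All three stay within the scatter, so the measured compounds give no sign that this place moves the number much. None of them, however, carries a five-membered aromatic ring here, which makes them a loose guide.

The expected change is therefore none beyond the scatter, and the estimate is a 1.5-fold lower number from compound 3 to compound 4 (0.17 log units; within the scatter). For compound 4 the expected value is 30000 nM, with an estimated range from 4000 nM to 60000 nM.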

Compound 4, half-maximal inhibitory concentration: 56200 nM
Estimate against measurement, compound 4: 1.9-fold (0.27 log units) below; the measured number falls inside the stated range.
By their numbers in this assay, from the lowest: compounds 2, 3, 1 and 4 (each within the scatter of the next).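

In this assay, thiophen-3-yl brings a five-membered aromatic ring with fewer heavy atoms to this carbon, and the result is a 1.3-fold higher number from compound 3 to compound 4 (0.11 log units; within the scatter). The steps from the two ethynyl compounds agree, with a 1.5-fold higher number from compound 2 to compound 4 (0.17 log units; within the scatter) and a 1.0-fold higher number from compound 1 to compound 4 (0.01 log units; within the scatter), so neither swapping the six-membered ring for the five-membered one nor removing the ethynyl link separates compound 4 from the other three. No other measurement here bears on why these four compounds cannot be told apart.

As far as these compounds go, all four groups at this carbon contain an aromatic ring, so it remains open whether a group of another kind, such as an amine, a carboxylic acid or a longer open chain, would move the number beyond the scatter. From the compounds shown here alone, all four compounds also carry the 3,4-dihydroxy-5-(hydroxymethyl)oxolan-2-yl group, so what a change at that site would do to the antiproliferative read-out also remains open.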